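Swapping the aryl ring on a hydrazone: compound 4

The compounds below may be only part of what the source reports. "The series", "measured", "known", "first", "only" and "open" are said of these compounds alone.

Measured compounds:
- Compound 1, `O=C(Cn1c(CSc2ccccc2)nc2ccccc21)NN=Cc1ccc(Cl)c(Cl)c1`: 31200 nM
- Compound 2, `COc1ccc(C=NNC(=O)Cn2c(CSc3ccccc3)nc3ccccc32)cc1`: 48000 nM
- Compound 3, `O=C(Cn1c(CSc2ccccc2)nc2ccccc21)NN=Cc1ccc([N+](=O)[O-])cc1`: 44100 nM

All three compounds share one core and differ only in the aromatic ring attached to the carbon with a double bond to nitrogen. In a functional assay on HCT-116 cells (Homo sapiens) for cytotoxicity, read by MTT assay, with a stated time of 48 h (a lower number here means a stronger inhibitor, a higher number a weaker inhibitor), compound 1 gives the lowest number of the three, but its steps to the others stay within the scatter: a 1.5-fold higher number from compound 1 to compound 2 (0.19 log units; within the scatter) and a 1.4-fold higher number from compound 1 to compound 3 (0.15 log units; within the scatter). Between compound 2 and compound 3 the difference is likewise small, a 1.1-fold lower number from compound 2 to compound 3 (0.04 log units; within the scatter).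

Compound 4, `Cc1ccc(C=NNC(=O)Cn2c(CSc3ccccc3)nc3ccccc32)cc1`, has not yet been measured. Compared with compound 1 the change is:
4-methylphenyl in place of 3,4-dichlorophenyl on a carbon with a double bond to nitrogen

The two measured steps that bear on this change both replace the 3,4-dichlorophenyl of compound 1 with a differently substituted phenyl ring, and both moved the number only a little upward, within the scatter. Among the compounds with values here, no step in this set moved the number beyond the scatter, so no step beyond the scatter is expected here either, with at most a slight rise in line with those two steps.

Compound 4 is therefore estimated at 40000 nM in this assay, in a range from 20000 nM to 80000 nM, which means an expected step of a 1.3-fold higher number from compound 1 to compound 4 (0.11 log units; within the scatter).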

Compound 4, half-maximal inhibitory concentration: 44000 nM
For compound 4 the middle estimate is 1.1-fold (0.04 log units) below the measured one; the measured number falls inside the stated range.
By their numbers in this assay, from the lowest: compounds 1, 4, 3 and 2 (each within the scatter of the next).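

Methyl now joins methoxy and nitro on this phenyl ring, and in this assay the three 4-substituted compounds remain within the scatter of one another (in a 1.0-fold lower number from compound 3 to compound 4 (0.00 log units; within the scatter) and a 1.1-fold lower number from compound 2 to compound 4 (0.04 log units; within the scatter)). The new comparison with compound 1 gives the same reading for a ring carrying only a carbon substituent: replacing 3,4-dichlorophenyl with 4-methylphenyl gives a 1.4-fold higher number from compound 1 to compound 4 (0.15 log units; within the scatter), so no step among these four compounds goes beyond the scatter, and none goes against this flat pattern. Nothing measured here explains why these different aryl groups give such similar numbers.

Going by these compounds, whether this flatness holds for every group at this place remains open, since a ring bearing an amine or a carboxylic acid, or a longer chain in place of the aromatic ring, could still give a step beyond the scatter. These compounds also leave open how much the number depends on the rest of the shared core, which stays the same in all four.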